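From Nitro to Methoxy: One Swap on Compound 1

The compounds below may be only part of what the source reports. "The series", "measured", "known", "first", "only" and "open" are said of these compounds alone.

In a functional assay on U-373MG ATCC cells (Homo sapiens) for inhibition, read by MTT assay, with a stated time of 72 h (on this read-out higher numbers stand for weaker inhibition and lower numbers for stronger inhibition), compound 1 `CC1(C)CC(NC(=S)Nc2cccc([N+](=O)[O-])c2)c2cc(Br)ccc2O1` gives 4000 nM. Within the data shown here, this is the lower of the two numbers measured so far, and the gap to compound 2 `CC1(C)CC(NC(=O)Nc2ccccc2Cl)c2cc(Br)ccc2O1`, which gives 19000 nM, lies beyond the usual scatter. Compound 1 therefore inhibits more strongly than compound 2. These two compounds differ in more than one place, so they cannot show what any single change does.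

Compound 3 `COc1cccc(NC(=S)NC2CC(C)(C)Oc3ccc(Br)cc32)c1` keeps the core of compound 1 but has methoxy in place of nitro on an aromatic carbon. Among the measured compounds shown here, no measured pair shows this swap, so any forecast is uncertain. A small step toward weaker inhibition is expected in this assay, estimated as a 1.8-fold higher number from compound 1 to compound 3 (0.24 log units; within the scatter). The expected value for compound 3 is 7000 nM, within an estimated range from 2500 nM to 20000 nM.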

Compound 3, half-maximal inhibitory concentration: 66000 nM
The estimate for compound 3 lay 9.4-fold (0.97 log units) below the measured number; the whole stated range lies below it.
By their numbers in this assay, from the lowest: compound 1; then compound 2; then compound 3.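

On this aromatic carbon, the choice of group matters greatly: in this assay methoxy in place of nitro gives a 17-fold higher number from compound 1 to compound 3 (1.22 log units; beyond the scatter) and thus much weaker inhibition, a large step beyond the usual scatter. Compound 1 and compound 2 differ in more than one place, so they could not tie a change in inhibition to this position, whereas this pair differs only here. Nothing measured here explains why the number rises so far.

One swap cannot show whether the loss is specific to methoxy or would follow from replacing nitro with another group, such as an amine, a nitrile or a plain hydrogen on the same carbon. It also leaves open whether methoxy in place of nitro would have a similar effect on a different core.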